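Working notes: a methyl on the quinolinyl group of compound 2

This account rests on a few compounds, and the source may have more. Where it says the series, first, only, none or still open, it means among the compounds named here.

Of the compounds shown here, two have numbers so far. In an ADME assay on Vero cells (Chlorocebus sabaeus) for cytotoxicity, read by MTT assay, with a stated time of 48 h (on this read-out higher numbers stand for lower toxicity in this test and lower numbers for higher toxicity in this test), compound 1 (`C=C1CC[C@@H]2[C@](C)(CO)[C@H](O)CC[C@@]2(C)[C@@H]1C/C=C1/C(=O)OC[C@H]1Oc1c(Cl)cc(Cl)c2cccnc12`) gives 82500 nM. Compound 2 (`C=C1CC[C@@H]2[C@](C)(COC(C)=O)[C@H](O)CC[C@@]2(C)[C@@H]1C/C=C1/C(=O)OC[C@@H]1Oc1cccc2cccnc12`) gives 27500 nM, the lower of the two numbers, and its gap to compound 1 lies beyond the scatter. Going by the values given here, no pair of measured compounds differs in only one place, so the data hold no direct precedent for a single change.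

Compound 3 (`C=C1CC[C@@H]2[C@](C)(COC(C)=O)[C@H](O)CC[C@@]2(C)[C@@H]1C/C=C1/C(=O)OC[C@@H]1Oc1cccc2ccc(C)nc12`) departs from compound 2 in one place, with quinolin-8-yl becoming 2-methylquinolin-8-yl: methyl in place of hydrogen on an aromatic carbon. This is methyl in place of hydrogen on an aromatic carbon, next to the ring nitrogen.

Among the compounds with values here, with no measured step to draw on, the starting point is compound 2 at 27500 nM. In this assay the expected step, a 1.1-fold lower number from compound 2 to compound 3 (0.04 log units; within the scatter), is estimated to stay within the scatter, and no firm direction is expected. For compound 3 the estimated value is 25000 nM, with an expected range from 11000 nM to 60000 nM.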

Compound 3, half-maximal cytotoxic concentration: 46500 nM
Beside the measured number, compound 3's estimate is 1.9-fold (0.27 log units) below it, and the stated range covers the measured number.
By their numbers in this assay, from the lowest: compounds 2, 3 and 1 (each within the scatter of the next, the first and the last beyond it).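

In this assay, the single listed step for methyl in place of hydrogen on an aromatic carbon is a 1.7-fold higher number from compound 2 to compound 3 (0.23 log units; within the scatter), so compounds 2 and 3 cannot be told apart at this position next to the ring nitrogen. Going by these compounds alone, this is the first pair that differs in only one place, and it shows that going from quinolin-8-yl to 2-methylquinolin-8-yl, with the rest of compound 2 held constant, leaves the number within the usual scatter, a reading that rests on this one pair alone. No measurement on hand accounts for this outcome, and the result therefore stands as an observation without an explanation.

On these data alone, whether a larger or different group on this aromatic carbon, such as an ethyl, a methoxy, a primary amine or a carboxylic acid, would take the number beyond the scatter remains open. Also open, as far as these compounds go, is whether the same methyl would give a comparable step on the core of compound 1, which carries two chlorines on its quinoline part and differs from compound 2 in several places.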